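Switching the Benzyl Group on a Sulfonamide Diamine

The source may report more compounds than this note shows. Statements on the series, on what has been measured and on what is new or still open speak of the compounds shown alone.

Of the compounds shown here, two have so far been tested in a functional assay on HPAC cells (Homo sapiens) for inhibition, read by MTT assay, with a stated time of 72 h; a higher number here means a weaker inhibitor of growth, a lower number a stronger inhibitor of growth. Compound 1 `O=S(=O)(NCCNCc1cccc2ccccc12)c1cc(C(F)(F)F)cc(C(F)(F)F)c1` gives 18000 nM. Compound 2 `O=S(=O)(NCCCNCc1ccccc1Cl)c1cc(C(F)(F)F)cc(C(F)(F)F)c1` gives 10000 nM; this number and that of compound 1 lie within the usual scatter of each other, so on these data the two cannot be told apart, and compound 2 simply holds the smaller of the two numbers. Compound 3 `CC(C)(C)c1ccc(CNCCCNS(=O)(=O)c2cc(C(F)(F)F)cc(C(F)(F)F)c2)cc1` has not yet been measured. It differs from compound 2 in one place: 4-(tert-butyl)phenyl in place of 2-chlorophenyl on a saturated chain carbon bound to an amine nitrogen. Among the measured compounds shown here, no measured pair shows a change of this kind, so there is no measured step to lean on. The expectation is a modest step, a 1.4-fold lower number from compound 2 to compound 3 (0.15 log units; within the scatter), one that may well stay within the scatter and could fall either way. Compound 3 is therefore estimated at 7000 nM, with a range from 2500 nM to 20000 nM.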

Compound 3, concentration for 50% growth inhibition: 2300 nM
Compound 3: the middle estimate sits 3.0-fold (0.48 log units) above what was measured; measured number below the stated range.
By their numbers in this assay, from the lowest: compound 3; then compounds 2 and 1 (each within the scatter of the next).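

In this assay, replacing 2-chlorophenyl with 4-(tert-butyl)phenyl on a saturated chain carbon bound to an amine nitrogen gives a 4.3-fold lower number from compound 2 to compound 3 (0.64 log units; beyond the scatter) and so moves the number clear of the usual scatter, which shows that the group at this position can matter for growth inhibition. Two things change together in this step, the kind of group on the ring and where it sits on the ring, so the step cannot be credited to either one alone. Nothing measured here explains the step.

Going by these compounds, an unsubstituted phenyl in the same place would help separate losing the chlorine from gaining the tert-butyl group, and how it would read remains open. On these data alone, whether a longer chain would keep the lower number also remains open.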